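This account rests on a few compounds, and the source may have more. Where it says the series, first, only, none or still open, it means among the compounds named here.

Compound 1 `NCC(=O)Nc1ccc(Cl)cc1C(=O)c1ccccc1` gives 29 mg/kg in a functional assay on the whole organism (strain CF-1) for inhibition, with Mus musculus as the target (a higher number here means that more compound is needed for the effect, a lower number that less compound is needed), and compound 3 `Cc1nnc(CN)n1-c1ccc(Cl)cc1C(O)c1ccccc1` gives 71 mg/kg in this assay. Compound 2 `CN(C)Cc1nnc(-c2ccco2)n1-c1ccc(Cl)cc1C(=O)c1ccccc1` reaches only the limit of the assay, > 100 mg/kg, and no number. On the numbers shown, compound 2 sits at the limit of > 100 mg/kg in this assay, at which 1 of the 3 values shown sits, so its position relative to compound 1 and compound 3 is not fixed. Compound 4 `Cc1nnc(CN(C)C)n1-c1ccc(Cl)cc1C(=O)c1ccccc1` has not yet been measured in this assay; it differs from compound 2 by methyl in place of furan-2-yl on an aromatic carbon. Among the compounds with values here, no step between measured compounds is known here, so the size of this change can only be guessed. The step from compound 2 to compound 4 is expected to be an at least 1.2-fold lower number from compound 2 to compound 4 (0.09 log units; that floor lies within the scatter). For compound 4 a value of 80 mg/kg is estimated, between 30 mg/kg and 200 mg/kg.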

Compound 4, dose for half-maximal effect: 45 mg/kg
Beside the measured number, compound 4's estimate is 1.8-fold (0.25 log units) above it, and the stated range covers the measured number.
By their numbers in this assay, from the lowest: compounds 1, 4 and 3 (each within the scatter of the next, the first and the last beyond it). At a limit, above all of these: compound 2.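

Within the data shown here, the step at this position, an aromatic carbon of the five-membered aromatic ring with 3 nitrogen, is the first single change available: methyl in place of furan-2-yl gives an at least 2.2-fold lower number from compound 2 to compound 4 (0.34 log units; beyond the scatter) in this assay. This shows that the group at this position can move the number beyond the scatter. The figure for compound 2 is a limit, so only a floor for the step is known: the limit of > 100 mg/kg in this assay, at which 1 of the 4 values shown sits.

The compounds shown leave open how the number responds to other groups here, such as ethyl, an amine or phenyl. They also leave open whether furan-2-yl as such matters, or any ring would do the same.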